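The source may hold more compounds than are shown below. What is called first, only, known or untested is meant among the compounds shown, and "the series" means these compounds.

Working notes on the series of glutamate-bearing benzoylamides sharing one core.

Compound 1, `CCN(Cc1ccc2nc(C)[nH]c(=O)c2c1)c1ccc(C(=O)N[C@@H](CCC(=O)O)C(=O)O)c(F)c1`, gives 45 nM in an assay on isolated protein for inhibition of Thymidylate synthase (Mus musculus); on this read-out lower numbers stand for stronger inhibition and higher numbers for weaker inhibition. Compound 2, `Cc1nc2ccc(CN(CC#N)c3ccc(C(=O)N[C@@H](CCC(=O)O)C(=O)O)c(F)c3)cc2c(=O)[nH]1`, gives 170 nM in this assay. Compound 3, `Cc1nc2ccc(CN(C)c3ccc(C(=O)N[C@@H](CCC(=O)O)C(=O)O)c(F)c3)cc2c(=O)[nH]1`, gives 120 nM in this assay, which places it second highest of the three numbers measured; its gap to compound 2 lies within the scatter, while its gap to compound 1 lies beyond it.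

Compound 4, `Cc1nc2ccc(CN(CCN)c3ccc(C(=O)N[C@@H](CCC(=O)O)C(=O)O)c(F)c3)cc2c(=O)[nH]1`, is the next member. Relative to compound 3 the change is aminomethyl in place of hydrogen on a saturated chain carbon bound to a nitrogen on an aromatic ring.

Going by the values given here, two measured steps touch this position. The step of a 2.7-fold higher number from compound 1 to compound 3 (0.43 log units; beyond the scatter) shows that a larger group on this carbon went with a smaller number, whereas the step of a 3.8-fold higher number from compound 1 to compound 2 (0.58 log units; beyond the scatter) shows that not every such group does so. The step of a 1.4-fold lower number from compound 2 to compound 3 (0.15 log units; within the scatter) adds little. Taken together, the expected step of a 1.2-fold lower number from compound 3 to compound 4 (0.08 log units; within the scatter) is small, with the direction uncertain. Compound 4 is estimated at 100 nM, within a range from 35 nM to 300 nM.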

Compound 4, half-maximal inhibitory concentration: 11700 nM
Beside the measured number, compound 4's estimate is 120-fold (2.07 log units) below it; measured number above the stated range.
By their numbers in this assay, from the lowest: compound 1; then compounds 3 and 2 (each within the scatter of the next); then compound 4.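

The 2-aminoethyl group falls well outside the narrow band set by the earlier groups on this carbon: in this assay, adding aminomethyl gives a 98-fold higher number from compound 3 to compound 4 (1.99 log units; beyond the scatter). Replacing cyano with aminomethyl gives a 69-fold higher number from compound 2 to compound 4 (1.84 log units; beyond the scatter), so this position does not accept every group of this chain length. The sharpest comparison is the amino group alone, in place of hydrogen on the ethyl chain, which gives a 260-fold higher number from compound 1 to compound 4 (2.41 log units; beyond the scatter); no data in hand account for a step of this size.

The compounds shown leave open whether a hydroxyl or a carboxylic acid at the end of the same chain would match the ethyl group or the 2-aminoethyl group. A longer chain ending in an amine, or an acetylated amine, also remains to be placed.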